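This account rests on a few compounds, and the source may have more. Where it says the series, first, only, none or still open, it means among the compounds named here.

Measured so far:
compound 1 `Cc1cc(NC(=O)Nc2ccc(F)cc2)c2ccccc2n1` — > 25000 nM
compound 2 `CC(=O)c1ccc(NC(=O)Nc2cc(C)nc3ccccc23)cc1` — > 25000 nM
compound 3 `Cc1cc(NC(=O)Nc2ccc(C(C)(C)C)cc2)c2ccccc2n1` — > 25000 nM

In an ADME assay on HEK293 cells (Homo sapiens) for cytotoxicity, with a stated time of 72 h (a higher number here means that more compound is needed for the effect, a lower number that less compound is needed), compound 1 gives > 25000 nM, which is a limit of the assay rather than a number. Compound 2 gives > 25000 nM, again a limit. Compound 3 gives > 25000 nM, also a limit. All three share (the limit of > 25000 nM in this assay, at which 3 of the 3 values shown sit), so the steps a step that the two limits leave unreadable from compound 1 to compound 2, a step that the two limits leave unreadable from compound 1 to compound 3 and a step that the two limits leave unreadable from compound 2 to compound 3 cannot be read in size or direction. Compound 4 `Cc1cc(NC(=O)Nc2cccc(F)c2)c2ccccc2n1` differs from compound 1 by 3-fluorophenyl in place of 4-fluorophenyl on an amide-type nitrogen. Among the measured compounds shown here, no measured step bears on this change, and nothing among compound 1, compound 2 and compound 3 points to a shift beyond the scatter in this assay. Compound 4 is therefore expected near the same limit, with an estimate of 30000 nM, between 15000 nM and 60000 nM, a step that the limit leaves unreadable from compound 1 to compound 4.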

Compound 4, half-maximal effective concentration: > 25000 nM
Compound 4 gave a limit, no number; the forecaster's own chance of this, stated with the estimate: 85%; the middle value lies beyond the limit too.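

Compound 4, like compound 1, gives a limit rather than a number, so the step between them cannot be read in size or direction. The compounds shown leave open how far apart they truly lie and which change on the shared core would give a readable value, since all stop at one limit: the limit of > 25000 nM in this assay, at which 4 of the 4 values shown sit.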